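A few compounds are considered here, and "the series" means these few. Any claim that something is new, unique, unknown or untested is made for them only; others in the source may bear on it.

Of the compounds shown here, two built on one shared core have so far been tested in an assay on membranes from HEK293 cells for displacement of a labelled ligand from adenosine receptor A2b (Homo sapiens), read by scintillation counting, with a stated time of 30 min; on this read-out lower numbers stand for stronger inhibition and higher numbers for weaker inhibition. Compound 1 `CC1=C(C(=O)C2CC2)C(c2ccco2)NC(=O)N1` gives 1060 nM. Among the compounds with values here, compound 2 `CC1=C(C(=O)CC(C)C)C(c2ccco2)NC(=O)N1` gives 240 nM, the lower of the two numbers; the single step between them, a 4.4-fold lower number from compound 1 to compound 2 (0.65 log units; beyond the scatter), came from putting isobutyl in place of cyclopropyl on a carbonyl carbon.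

Compound 3 `CCC(C)OC(=O)C1=C(C)NC(=O)NC1c1ccco1` has not yet been measured. It differs from compound 2 by sec-butoxy in place of isobutyl on a carbonyl carbon, so the group on the carbonyl carbon changes once more, this time with an oxygen entering the link between the carbonyl carbon and the chain. Within the data shown here, the step from compound 1 to compound 2 is the only measured step touching this position, and it was of modest size; no measured pair shows what placing an oxygen there does. The expected step of a 1.7-fold higher number from compound 2 to compound 3 (0.22 log units; within the scatter) is therefore kept small and uncertain, leaning towards a somewhat higher number. The estimate for compound 3 in this assay is 400 nM, expected to fall between 120 nM and 1300 nM.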

Compound 3, inhibition constant: 84.3 nM
For compound 3 the middle estimate is 4.7-fold (0.68 log units) above the measured one, and the stated range ends above it.
By their numbers in this assay, from the lowest: compound 3; then compound 2; then compound 1.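

In this assay the group on the carbonyl carbon has now changed a second time, and moving from isobutyl to sec-butoxy gives a 2.8-fold lower number from compound 2 to compound 3 (0.45 log units; beyond the scatter). Within the data shown here, the new group keeps the four carbons of isobutyl and adds an oxygen as the link to the carbonyl carbon, so this result is the first to show that a group with this oxygen link can give a lower number than a group without it. Set against cyclopropyl, sec-butoxy gives a 13-fold lower number from compound 1 to compound 3 (1.10 log units; beyond the scatter), a wider span at this one position than the first pair of compounds revealed, though no supporting measurement is available to explain the change.

Isobutyl and sec-butoxy differ in the oxygen and also in the shape of the chain, so these compounds cannot separate one from the other, whereas isobutoxy, which would keep the isobutyl chain and add the oxygen, could begin to do so. Also open, going by these compounds, is how this position responds to other groups on the carbonyl carbon, such as a shorter ethoxy chain, a longer chain joined through oxygen, or an amine in place of the oxygen.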